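A few compounds are considered here, and "the series" means these few. Any claim that something is new, unique, unknown or untested is made for them only; others in the source may bear on it.

In a functional assay on the whole organism for inhibition, with Rattus norvegicus as the target, read by cytopathic effect and paw edema, at a dose of 100 mg/kg by the oral route (on this read-out higher numbers stand for more inhibition at the one dose given (going by the name of the read-out) and lower numbers for less inhibition), the three measured compounds give the following numbers:
Compound 1 `O=C(NC1CCN(Cc2ccccc2)CC1)c1c(O)c2cccnc2n(-c2ccccc2)c1=O` gives 1.2%.
Compound 2 `O=C(Nc1ccc(Cl)cc1)c1c(O)c2cccnc2n(-c2ccccc2)c1=O` gives 2.5%.
Compound 3 `O=C(Nc1nccs1)c1c(O)c2cccnc2n(-c2ccccc2)c1=O` gives 2.5%.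

Compound 2 stands level with compound 3, and compound 1 lies within the usual scatter of both, so none of the three can be set apart from the others. Compound 4 `O=C(Nc1cnccn1)c1c(O)c2cccnc2n(-c2ccccc2)c1=O` differs from compound 2 in one place: pyrazin-2-yl in place of 4-chlorophenyl on an amide-type nitrogen. Going by the values given here, one measured step bears on this change, the one from compound 2 to compound 3, where a ring with hetero atoms also took the place of 4-chlorophenyl on the amide-type nitrogen: no change at the digits printed from compound 2 to compound 3 (within the scatter). On that basis no step beyond the scatter is expected, and the expected step is no change at the digits printed from compound 2 to compound 4 (within the scatter). Compound 4 is therefore estimated at 2.5%, with a range from 0% to 12%.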

Compound 4, a percentage reported as inhibition, in the whole organism at one dose (the size of the read-out at that dose, not a potency): 21.2%
Beside the measured number, compound 4's estimate is 18.7 percentage points below it; measured number outside the range, above it.
By their numbers in this assay, from the lowest: compounds 1, 2 and 3 (each within the scatter of the next); then compound 4.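

In this assay, the group on the amide-type nitrogen can shift the number: pyrazin-2-yl in place of 4-chlorophenyl gives a number 18.7 percentage points higher from compound 2 to compound 4 (beyond the scatter), and pyrazin-2-yl in place of 1,3-thiazol-2-yl gives a number 18.7 percentage points higher from compound 3 to compound 4 (beyond the scatter). A ring with hetero atoms at this place is therefore not enough on its own, and the outcome depends on which ring it is. Nothing available here explains why pyrazin-2-yl stands apart. Going by these compounds, whether pyrimidin-2-yl or pyridin-2-yl on the same nitrogen would match pyrazin-2-yl stays open, as does the effect of an amine on the pyrazin-2-yl ring.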